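The source may hold more compounds than are shown below. What is called first, only, known or untested is meant among the compounds shown, and "the series" means these compounds.

Three compounds share one core, and a fourth is still to be measured. Compound 2 `CS(=O)(=O)c1ccc(Nc2nccc(Nc3nc4ccccc4s3)n2)cc1` gives 8370 nM in a functional assay on HCT-116 cells (Homo sapiens) for antiproliferative activity, read by MTT assay, with a stated time of 48 h; on this read-out higher numbers stand for weaker inhibition and lower numbers for stronger inhibition. Compound 1 `CS(=O)(=O)c1ccc(Nc2ncc(F)c(Nc3nc4ccccc4s3)n2)cc1` differs from it by fluoro in place of hydrogen on an aromatic carbon, and on this read-out compound 1 gives 3270 nM, a step of a 2.6-fold lower number from compound 2 to compound 1 (0.41 log units; beyond the scatter). Compound 3 `NS(=O)(=O)c1ccc(Nc2nccc(Nc3nc4ccccc4s3)n2)cc1` differs from compound 2 by amino in place of methyl on a sulfonyl sulfur; in this assay compound 3 gives 5170 nM, and the step of a 1.6-fold lower number from compound 2 to compound 3 (0.21 log units; within the scatter) is one the assay cannot resolve with confidence.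

Compound 4 `NS(=O)(=O)c1ccc(Nc2nccc(Nc3nc4ccc(F)cc4s3)n2)cc1` differs from compound 3 by fluoro in place of hydrogen on an aromatic carbon. This is the same kind of change as from compound 2 to compound 1, but not the same: there the fluoro entered on a six-membered aromatic ring with two nitrogen, ortho to a large group, two atoms from the ring nitrogen and para to a large group, whereas here it enters on a six-membered aromatic ring of carbon only, part of a fused system of two rings, meta and para to a fused ring. For the measured compounds named here, the one measured step of this kind is a guide of limited reach. Compound 4 is therefore expected to give about 3500 nM in this assay, between 1500 nM and 9000 nM, a step of a 1.5-fold lower number from compound 3 to compound 4 (0.17 log units; within the scatter), resting on the earlier step of a 2.6-fold lower number from compound 2 to compound 1 (0.41 log units; beyond the scatter) and on the value of compound 3, 5170 nM.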

Compound 4, half-maximal inhibitory concentration: 700 nM
Beside the measured number, compound 4's estimate is 5.0-fold (0.70 log units) above it; the whole stated range lies above it.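

In this assay, fluoro in place of hydrogen on an aromatic carbon lowers the number on both cores, and the new step is a 7.4-fold lower number from compound 3 to compound 4 (0.87 log units; beyond the scatter). The direction is shared, but the size of the step does not carry over from one core to the other: the same change on two cores in this assay, a 2.6-fold lower number (0.41 log units; beyond the scatter) from compound 2 to compound 1 and a 7.4-fold lower number (0.87 log units; beyond the scatter) from compound 3 to compound 4, 2.9-fold (0.46 log units) apart, beyond the scatter of two such steps These two pairs differ both in the ring that carries the fluoro and in the group on the sulfonyl sulfur, so they cannot show which of the two goes with the larger step, and they give no rule for any further core.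

The compounds shown leave open what the fluoro of compound 4 would give, at the same place, with the methyl on the sulfonyl sulfur of compound 2, and what the fluoro of compound 1 would give with the amino on the sulfonyl sulfur of compound 3. They also leave open whether a chloro or methoxy group in place of the fluoro of compound 4 would give a step of similar size.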